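The compounds below may be only part of what the source reports. "The series", "measured", "known", "first", "only" and "open" are said of these compounds alone.

Series notes. Two amides built on a shared core have been run in a functional assay on HEK293 cells for agonist activity at D(4) dopamine receptor (Homo sapiens), read by FLIPR (on this read-out lower numbers stand for smaller maximal responses and higher numbers for larger maximal responses), so far. Compound 1 `O=C(NCN1CCC(c2cccc[n+]2[O-])CC1)c1cnccc1Cl` gives 44% in this assay. Compound 2 `O=C(NCN1CCC(c2cccc[n+]2[O-])CC1)c1ccc2ccccc2c1` gives 67% in this assay. Among the compounds with values here, compound 1 therefore stands lowest of the two numbers, with compound 2 as its only neighbour and that one higher by a gap beyond the usual scatter of the read-out. Within the data shown here, no pair of measured compounds differs in a single place, so no measured step is available to calibrate any change at the carbonyl carbon.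

Compound 3 `Cc1cc(C(=O)NCN2CCC(c3cccc[n+]3[O-])CC2)ccc1Cl` has not been measured in this assay. Relative to compound 1 it differs as follows: 4-chloro-3-methylphenyl in place of 4-chloropyridin-3-yl on a carbonyl carbon.

Among the measured compounds shown here, with no measured step of this kind, the expectation for compound 3 rests only on the two values in hand, where compound 1 sits at 44% and compound 2 at 67%. A modest upward step is expected from compound 1 to compound 3, estimated at a number 8 percentage points higher from compound 1 to compound 3 (within the scatter) in this assay. Compound 3 is thus expected to reach about 52% in this assay, within a range from 30% to 75%.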

Compound 3, largest response reached (reported as efficacy), in percent of the reference or control that the assay uses: 62%
Compound 3: the middle estimate sits 10 percentage points below what was measured; measured number inside the range.
By their numbers in this assay, from the lowest: compound 1; then compounds 3 and 2 (each within the scatter of the next).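

Within the data shown here, replacing 4-chloropyridin-3-yl with 4-chloro-3-methylphenyl on a carbonyl carbon gives the first one-place step: in this assay the change is a number 18 percentage points higher from compound 1 to compound 3 (beyond the scatter), so the maximal response does shift with the group at this position. The step is a compound change, since the ring nitrogen leaves and a methyl group enters together, and a single pair cannot assign the shift to either part. Nothing measured in the series bears on why the response moves with this exchange.

On these data alone, it remains open how much of the step belongs to the ring nitrogen and how much to the methyl group; a 4-chlorophenyl group on the same carbonyl carbon, holding the chlorine but neither of those two features, would divide the step into its two parts. As far as these compounds go, it is also open whether the chlorine contributes at all, a question that a plain phenyl or a 3-methylphenyl group at this position would address against the same shared core.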